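Pyrazinyl in place of pyridinyl on the imidazoline ether

This account rests on a few compounds, and the source may have more. Where it says the series, first, only, none or still open, it means among the compounds named here.

Of the compounds shown here, three have so far been measured in a functional assay for activation of Alpha-1B adrenergic receptor (Homo sapiens), read by calcium flux; a higher number here means that more compound is needed for the effect, a lower number that less compound is needed. Compound 1 `CCN(CC)C(=O)c1ccccc1OCC1=NCCN1` gives only a limit of the assay, < 5020 nM. Compound 3 `Cc1cccc(-c2ccccc2OCC2=NCCN2)n1` likewise gives only a limit, < 100000 nM. Compound 2 `c1ccc(-c2ccncc2)c(OCC2=NCCN2)c1`, the starting point of this account, also gives only a limit, < 100000 nM. On the numbers shown, compound 2 stands at the limit of < 100000 nM in this assay, at which 2 of the 3 values shown sit, whereas compound 1 sits at the limit of < 5020 nM in this assay, at which 1 of the 3 values shown sits.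

Compound 4 `c1ccc(-c2cnccn2)c(OCC2=NCCN2)c1` differs from compound 2 by pyrazin-2-yl in place of pyridin-4-yl on an aromatic carbon. Among the compounds with values here, no measured step of this kind exists among the three compounds. From compound 2 to compound 4 the expected step is none beyond the scatter, a step that the limit leaves unreadable from compound 2 to compound 4. Compound 4 is therefore estimated at 30000 nM, with a range from 3000 nM to 100000 nM.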

Compound 4, half-maximal effective concentration: 631 nM
Compound 4: the middle estimate sits 48-fold (1.68 log units) above what was measured; measured number outside the range, below it.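

In this assay, within the data shown here, compound 2 gives only a limit of the assay, < 100000 nM, and no step from it to compound 4 can be read. The compounds shown leave open how far pyrazin-2-yl and pyridin-4-yl actually differ.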